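Moving a Chlorine Atom in a Weak Antiproliferative Series

The compounds below may be only part of what the source reports. "The series", "measured", "known", "first", "only" and "open" are said of these compounds alone.

Measured so far in a functional assay on HT-29 cells (Homo sapiens) for antiproliferative activity, read by sulforhodamine B assay, with a stated time of 48 h; on this read-out lower numbers stand for stronger inhibition of growth and higher numbers for weaker inhibition of growth:
compound 1, `NS(=O)(=O)NCC1CCN(c2cc(-c3ccc(Cl)cc3)ncn2)CC1`, gives 37700 nM;
compound 2, `NS(=O)(=O)NCC1CCN(c2cc(-c3cccc(Cl)c3)ncn2)CC1`, gives 47500 nM;
compound 3, `NS(=O)(=O)NCCC1CCN(c2cc(-c3ccc(Cl)cc3)ncn2)CC1`, gives 30500 nM.

All three numbers lie close together. From compound 1 to compound 2 the change is 3-chlorophenyl in place of 4-chlorophenyl on an aromatic carbon, and in this assay it gave a 1.3-fold higher number from compound 1 to compound 2 (0.10 log units; within the scatter). Compound 3 differs from compound 1 in its core by (sulfamoylamino)methyl in place of sulfamoylamino on a saturated chain carbon bound to a saturated ring carbon, with a 1.2-fold lower number from compound 1 to compound 3 (0.09 log units; within the scatter). Compound 4, `NS(=O)(=O)NCCC1CCN(c2cc(-c3cccc(Cl)c3)ncn2)CC1`, is not yet measured; it differs from compound 3 by 3-chlorophenyl in place of 4-chlorophenyl on an aromatic carbon, the same change seen between compound 1 and compound 2, at the same place.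

Because the earlier step was a 1.3-fold higher number from compound 1 to compound 2 (0.10 log units; within the scatter), compound 4 is expected to sit near compound 3, with an estimated step of a 1.2-fold higher number from compound 3 to compound 4 (0.10 log units; within the scatter). The estimate for compound 4 in this assay is 38000 nM, most likely between 19000 nM and 76000 nM.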

Compound 4, concentration for 50% growth inhibition: 31600 nM
The estimate for compound 4 lay 1.2-fold (0.08 log units) above the measured number, within the range that was stated.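

In this assay, swapping 4-chlorophenyl for 3-chlorophenyl on the core of compound 3 gave a 1.0-fold higher number from compound 3 to compound 4 (0.02 log units; within the scatter), which agrees with the earlier step: the same change on two cores in this assay, a 1.3-fold higher number (0.10 log units; within the scatter) from compound 1 to compound 2 and a 1.0-fold higher number (0.02 log units; within the scatter) from compound 3 to compound 4, 1.2-fold (0.08 log units) apart, within the scatter of two such steps

Adding the extra chain carbon to the core of compound 2 gave a 1.5-fold lower number from compound 2 to compound 4 (0.18 log units; within the scatter), which also agrees with the earlier step: the same change on two cores in this assay, a 1.2-fold lower number (0.09 log units; within the scatter) from compound 1 to compound 3 and a 1.5-fold lower number (0.18 log units; within the scatter) from compound 2 to compound 4, 1.2-fold (0.08 log units) apart, within the scatter of two such steps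

Neither change has a detectable effect on either core, so this agreement shows only that the absence of an effect carries over, not that a change with a real effect would carry over in the same way.

On these data alone, it remains open whether a nitrile or a methoxy group in place of the chlorine would shift growth inhibition beyond the scatter. The same question stands for a longer chain, or an amine in place of the sulfamoylamino group.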